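Swapping Phenyl for Furan-2-yl on Compound 1

The compounds below may be only part of what the source reports. "The series", "measured", "known", "first", "only" and "open" are said of these compounds alone.

Compound 1 `COc1nc(N)nc2c1c(-c1ccccc1)cn2[C@@H]1O[C@H](CO)[C@@H](O)[C@H]1O` stands at a limit of the assay: in a functional assay on K562 cells (Homo sapiens), read by MTT assay, with a stated time of 72 h (on this read-out higher numbers stand for weaker inhibition and lower numbers for stronger inhibition), compound 1 gives > 20000 nM. Compound 3 `Nc1nc(N)c2c(-c3ccccc3)cn([C@@H]3O[C@H](CO)[C@@H](O)[C@H]3O)c2n1` also reaches only a limit, giving > 20000 nM in this assay. Compound 2 `Cc1ncnc2c1c(-c1ccsc1)cn2[C@@H]1O[C@H](CO)[C@@H](O)[C@H]1O` gives 5550 nM in this assay. For the measured compounds named here, the sole single-point step, a step that the two limits leave unreadable from compound 1 to compound 3, cannot be read because of the limit of > 20000 nM in this assay, at which 2 of the 3 values shown sit. Compound 4 `COc1nc(N)nc2c1c(-c1ccco1)cn2[C@@H]1O[C@H](CO)[C@@H](O)[C@H]1O` differs from compound 1 by furan-2-yl in place of phenyl on an aromatic carbon. Going by the values given here, no measured step bears on this change, and compound 2 differs from compound 1 in more than one place. The writer therefore expects no movement beyond the scatter, with a step that the limit leaves unreadable from compound 1 to compound 4 expected to be small. Compound 4 is estimated at 25000 nM, between 8000 nM and 60000 nM.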

Compound 4, half-maximal inhibitory concentration: > 20000 nM
Compound 4: only a limit was reported (the forecaster's own chance of this, stated with the estimate: 65%); the middle value does not contradict the limit.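

Compound 1 and compound 4 both reach only a limit, so no step between them can be read, because both sit at the same limit: the limit of > 20000 nM in this assay, at which 3 of the 4 values shown sit.

On these data alone, whether furan-2-yl in place of phenyl on the shared core changes inhibition at all remains open.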